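The source may report more compounds than this note shows. Statements on the series, on what has been measured and on what is new or still open speak of the compounds shown alone.

Compound 1 `Brc1cn2ccnc2c(-c2ccc3ncn(C4CCCCC4)c3c2)n1` gives 7.68% in a functional assay on CCRF-CEM cells (Homo sapiens) for inhibition, read by sulforhodamine B assay, with a stated time of 48 h, tested at 10 uM; on this read-out lower numbers stand for less inhibition and higher numbers for more inhibition at the one concentration tested (going by the name of the read-out). Compound 2 `c1ccc2c(-c3cn4ccnc4c(-c4ccc5ncn(C6CCCCC6)c5c4)n3)cccc2c1` gives 17.5%. Compound 3 `Fc1ccc(-c2cn3ccnc3c(-c3ccc4ncn(C5CCCCC5)c4c3)n2)cc1` gives 33.4%.

Compound 3 stands highest of the three: a number 25.7 percentage points higher from compound 1 to compound 3 (beyond the scatter) and a number 15.9 percentage points higher from compound 2 to compound 3 (beyond the scatter) are both beyond the scatter, while a number 9.8 percentage points higher from compound 1 to compound 2 (within the scatter) stays within it. Compound 4 `c1cn2cc(-c3ccsc3)nc(-c3ccc4ncn(C5CCCCC5)c4c3)c2n1` differs from compound 3 in one place: thiophen-3-yl in place of 4-fluorophenyl on an aromatic carbon. Every measured step swaps the group at this same place, so all three bear on it, yet none puts thiophen-3-yl in for 4-fluorophenyl, and the spread among the groups already tried is modest. A modest drop is therefore expected in this assay, though a step within the scatter cannot be ruled out. Compound 4 is expected to give 22%, between 5% and 40%. This expected step is a number 11.4 percentage points lower from compound 3 to compound 4 (beyond the scatter).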

Compound 4, a percentage reported as inhibition, at one concentration (the size of the read-out at that concentration, not a potency): 29.2%
Beside the measured number, compound 4's estimate is 7.2 percentage points below it; the range from low to high includes it.
By their numbers in this assay, from the lowest: compounds 1 and 2 (each within the scatter of the next); then compounds 4 and 3 (each within the scatter of the next).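

In this assay, thiophen-3-yl and 4-fluorophenyl cannot be told apart at this position, with a number 4.2 percentage points lower from compound 3 to compound 4 (within the scatter), so a five-membered aromatic ring with sulfur does as well here as a six-membered carbon ring bearing fluorine. Thiophen-3-yl also stands clear of the other two groups, with a number 11.7 percentage points higher from compound 2 to compound 4 (beyond the scatter) and a number 21.5 percentage points higher from compound 1 to compound 4 (beyond the scatter) in the same assay. Nothing available explains these differences.

As far as these compounds go, whether an amine or a carboxylic acid on the aromatic ring at this position would raise or lower the number remains open. So does whether these groups keep their order at other concentrations.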